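The compounds below may be only part of what the source reports. "The series", "measured", "known", "first", "only" and "open" are said of these compounds alone.

Compound 3 `CCCNC(=O)c1oc2ccc(Nc3ncnc4ccc(Cl)nc34)cc2c1C` carries a propylamino group on the carbonyl carbon of the shared core. In an assay on isolated protein for inhibition of MAP kinase-interacting serine/threonine-protein kinase 1 (Homo sapiens), read by HTRF, in the presence of a further agent that is not named here (on this read-out lower numbers stand for stronger inhibition and higher numbers for weaker inhibition), compound 3 gives > 10000 nM, which is a limit of the assay and not a number. Compound 1 `Cc1c(C(=O)N2CCOCC2)oc2ccc(Nc3ncnc4ccc(Cl)nc34)cc12` bears a morpholin-4-yl group on the same carbonyl carbon, and in this assay compound 1 gives > 10000 nM, again a limit. Compound 2 `Cc1c(C(=O)N2CCNCC2)oc2ccc(Nc3ncnc4ccc(Cl)nc34)cc12` bears a piperazin-1-yl group there, and in this assay compound 2 gives > 10000 nM, also a limit. The steps a step that the two limits leave unreadable from compound 1 to compound 2, a step that the two limits leave unreadable from compound 1 to compound 3 and a step that the two limits leave unreadable from compound 2 to compound 3 therefore cannot be sized, because every value sits at the limit of > 10000 nM in this assay, at which 3 of the 3 values shown sit. Compound 4 `CNC(=O)c1oc2ccc(Nc3ncnc4ccc(Cl)nc34)cc2c1C` differs from compound 3 by hydrogen in place of ethyl on a saturated chain carbon bound to an amide-type nitrogen. No measured change at this carbonyl carbon has lifted any compound off the limit, so compound 4 is expected to remain there as well, with an expected step that the limit leaves unreadable from compound 3 to compound 4 that cannot be told from none. Compound 4 is estimated at 15000 nM, within a range from 5000 nM to 50000 nM, and most probably reported only as a limit.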

Compound 4, half-maximal inhibitory concentration: > 10000 nM
Compound 4: only a limit was reported; the forecaster's own chance of this, stated with the estimate: 80%; the middle value is on the limit's open side.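

Compound 4 also gives only a limit, so the steps linking it to compound 1, compound 2 and compound 3 cannot be read, because all the values stand at the same point: the limit of > 10000 nM in this assay, at which 4 of the 4 values shown sit.

The compounds shown leave open whether any group on this carbonyl carbon, or any change elsewhere on the shared core, would bring a compound off that limit.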